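Swapping the aryl group on the ring amine of compound 2

A few compounds are considered here, and "the series" means these few. Any claim that something is new, unique, unknown or untested is made for them only; others in the source may bear on it.

Compound 1, `CC(C)Cc1ccc(C(C)C(=O)NCc2ccc(Cl)c(Cl)c2)cc1`: 36000 nM
Compound 2, `CC(C)Cc1ccc(C(C)C(=O)N2CCN(c3ccc(Cl)c(Cl)c3)CC2)cc1`: 16000 nM

In an assay on brain for inhibition of Fatty-acid amide hydrolase 1 (Rattus norvegicus), read by scintillation counting, with a stated time of 10 min (on this read-out higher numbers stand for weaker inhibition and lower numbers for stronger inhibition), compound 2 gives the lower of the two numbers, and compound 1 gives a higher number, a gap beyond the usual scatter. Compound 3, `Cc1cccc(N2CCN(C(=O)C(C)c3ccc(CC(C)C)cc3)CC2)c1C`, differs from compound 2 by 2,3-dimethylphenyl in place of 3,4-dichlorophenyl on an amine nitrogen in a ring, in words 2,3-dimethylphenyl in place of 3,4-dichlorophenyl on an amine nitrogen in a ring. Among the measured compounds shown here, no measured pair shows this change, so a modest step at most is expected, likely within the scatter, leaning toward a weaker result. Compound 3 is expected near 25000 nM, within 8000 nM to 80000 nM, an expected step of a 1.6-fold higher number from compound 2 to compound 3 (0.19 log units; within the scatter).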

Compound 3, half-maximal inhibitory concentration: 1700 nM
Compound 3: middle estimate off by 15-fold (1.17 log units), on the high side; the whole stated range lies above it.
By their numbers in this assay, from the lowest: compound 3; then compound 2; then compound 1.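

Putting 2,3-dimethylphenyl in place of 3,4-dichlorophenyl on the amine nitrogen in the ring gives a 9.4-fold lower number from compound 2 to compound 3 (0.97 log units; beyond the scatter) in this assay, a step beyond the usual scatter. This position therefore responds strongly to the aryl group it carries, even though both groups have 8 heavy atoms and neither has a hydrogen-bond donor or acceptor. No supporting measurement bears on the reason for this result. As far as these compounds go, the swap changes both the substituents and where they sit, so the contribution of each remains open. From the compounds shown here alone, how a 3,4-dimethylphenyl, 2,3-dichlorophenyl or methoxyphenyl group would behave at this position also remains open.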